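This account rests on a few compounds, and the source may have more. Where it says the series, first, only, none or still open, it means among the compounds named here.

Working notes on the series, read in a functional assay on MCF7 cells (Homo sapiens) for cytotoxicity, read by MTT assay, with a stated time of 24 h; on this read-out higher numbers stand for weaker inhibition and lower numbers for stronger inhibition. Compound 3 `O=C(Nc1cccc(C(F)(F)F)c1)Nc1cccc2c(Oc3ccc([N+](=O)[O-])cc3)cccc12` gives 953 nM. Compound 1 `O=C(Nc1ccccc1)Nc1cccc2c(O)cccc12` gives 953 nM and compound 2 `O=C(Nc1ccc(Cl)c(C(F)(F)F)c1)Nc1cccc2c(Oc3ccc([N+](=O)[O-])cc3)cccc12` gives 953 nM, so compound 3 stands level with both at the digits available, and the three values offer no ranking.

The next compound to read is compound 4 `O=C(Nc1ccccc1)Nc1cccc2c(Oc3ccc([N+](=O)[O-])cc3)cccc12`. The structural change is hydrogen in place of trifluoromethyl on an aromatic carbon, meta to a large group, so that 3-(trifluoromethyl)phenyl becomes phenyl.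

Among the measured compounds shown here, one measured step bears on this: no change at the digits printed from compound 2 to compound 3 (within the scatter), where hydrogen takes the place of chloro on an aromatic carbon. That step removes a different group, and it is the only one of its kind, so it serves as a guide and not as a rule. On that single step, no shift beyond the scatter is expected in this assay, and no direction is favoured. The expected change is no change at the digits printed from compound 3 to compound 4 (within the scatter). Compound 4 is estimated at 953 nM, with an expected range of 450 nM to 2000 nM.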

Compound 4, half-maximal inhibitory concentration: 953 nM
Estimate against measurement, compound 4: no gap at the digits printed; the measured number falls inside the stated range.
By their numbers in this assay, from the lowest: compounds 1, 2, 3 and 4 (each within the scatter of the next).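

In this assay the step to phenyl at this position gives no change at the digits printed from compound 3 to compound 4 (within the scatter) when trifluoromethyl alone leaves, so this group, like the chloro of the earlier step, has no readable effect on the value here. The wider change of 4-chloro-3-(trifluoromethyl)phenyl to phenyl on the amide-type nitrogen gives no change at the digits printed from compound 2 to compound 4 (within the scatter) and shows that taking off both groups together also leaves the value unmoved within the scatter. Among the compounds shown here, at the other end of the molecule, with phenyl held constant, 4-nitrophenyl in place of hydrogen on the oxygen gives no change at the digits printed from compound 1 to compound 4 (within the scatter) and adds a first reading of this second site, where the presence of a whole aromatic ring leaves the printed number as it was. No supporting measurement is available to explain these matching values.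

From the compounds shown here alone, whether an amine or a carboxylic acid in place of the nitro group, or a longer alkyl chain in place of phenyl on the nitrogen, would give a step beyond the scatter remains open. Also open is whether any change to this series separates compounds on this read-out, as all four compounds shown print the same number.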